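From 2-aminophenyl to 4-methylphenyl on the shared core

The compounds below may be only part of what the source reports. "The series", "measured", "known", "first", "only" and "open" are said of these compounds alone.

In a functional assay on MDA-MB-231 cells (Homo sapiens) for cytotoxicity, read by MTT assay, with a stated time of 48 h (a lower number here means a stronger inhibitor, a higher number a weaker inhibitor), compound 1 `Fc1cccc(-c2nc(Nc3ccccc3F)c3cc(F)ccc3n2)c1` gives > 50000 nM, which is a limit and not a number. Compound 2 `Nc1ccccc1Nc1nc(-c2cccc(F)c2)nc2ccc(F)cc12` gives > 50000 nM, which is also only a limit. The evidence so far amounts to the limit of > 50000 nM in this assay, at which 2 of the 2 values shown sit. For the measured compounds named here, the single measured step, a step that the two limits leave unreadable from compound 1 to compound 2, therefore offers no size to carry forward and no direction. Compound 3 `Cc1ccc(Nc2nc(-c3cccc(F)c3)nc3ccc(F)cc23)cc1` has 4-methylphenyl in place of 2-aminophenyl on a nitrogen on an aromatic ring. Going by the values given here, no measured compound yet carries this new group, so the expectation rests only on both measured neighbours lacking a readable value in this assay. The expected step is a number no higher from compound 2 to compound 3 (the limit leaves the size open), with little confidence in its direction. For compound 3 the estimate is 50000 nM, with an expected range of 15000 nM to 100000 nM, and another limit would be no surprise.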

Compound 3, half-maximal inhibitory concentration: > 50000 nM
Compound 3 ended at the assay's limit (the forecaster's own chance of this, stated with the estimate: 65%); the middle value sits exactly at the limit.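

Compound 3, like compound 1 and compound 2, gives only a limit in this assay, so no step among these three compounds can be read. The compounds shown leave open whether any group on that nitrogen changes the cytotoxicity, since all that stands is this: the limit of > 50000 nM in this assay, at which 3 of the 3 values shown sit.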